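A few compounds are considered here, and "the series" means these few. Any claim that something is new, unique, unknown or untested is made for them only; others in the source may bear on it.

Series notes, shared core with a butenolide side chain.

Going by the values given here, compound 1 `C=C1CC[C@@H]2[C@](C)(CO)[C@H](O)CC[C@@]2(C)[C@@H]1/C=C/C1=CC(=C(C)C)OC1=O` carries an isopropylidene-type substituent on the lactone and is the only member of the set with a numerical reading: in an assay on isolated protein for inhibition of Maltase-glucoamylase (Homo sapiens), tested at 100 uM (on this read-out higher numbers stand for more inhibition at the one concentration tested (going by the name of the read-out) and lower numbers for less inhibition), compound 1 gives 17.1%. Compound 2 `C=C1CC[C@@H]2[C@](C)(CO)[C@H](O)CC[C@@]2(C)[C@@H]1/C=C/C1=C/C(=C/C=C(/C)CCC=C(C)C)OC1=O` carries the longer 2,6-dimethylhepta-1,5-dien-1-yl chain at the same position; in this assay compound 2 is recorded as "not active" (no number reported), so no single number is available for it, and its standing relative to compound 1 can only be described as lower in the qualitative sense, with no step size attached.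

Compound 3 `C=C1CC[C@@H]2[C@](C)(CO)[C@H](O)CC[C@@]2(C)[C@@H]1/C=C/C1=C/C(=C/c2ccc(OC)cc2)OC1=O` is the next member, not yet measured in this assay. It differs from compound 2 as follows: 4-methoxyphenyl in place of 2,6-dimethylhepta-1,5-dien-1-yl on a double-bonded chain carbon bound to a double-bonded ring carbon.

Among the compounds with values here, no step between measured compounds exists to anchor this change. The two readings in hand, a modest figure for compound 1 and no activity for compound 2, suggest that any step from compound 2 to compound 3 in this assay is expected to be small and, if anything, upward, with a fair chance it stays within the scatter or is again reported only as inactive. Compound 3 is therefore expected to give about 12% in this assay, within an estimated range from 0% to 30%.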

Compound 3, a percentage reported as inhibition, at one concentration (the size of the read-out at that concentration, not a potency): 100%
Compound 3: the middle estimate sits 88 percentage points below what was measured, outside the stated range (above it).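

In this assay, going by these compounds alone, compound 2 is recorded as "not active" (no number reported) and compound 3 gives 100% with no number on the compound 2 side, so no step between compound 2 and compound 3 can be read. The compounds shown leave open what potency lies behind the reading for compound 3. Nothing at hand bears on the cause of this result.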